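A Mirror-Image Change at One Carbon of Compound 3

The source may report more compounds than this note shows. Statements on the series, on what has been measured and on what is new or still open speak of the compounds shown alone.

In an assay on isolated protein for inhibition of Amine oxidase [flavin-containing] A (Homo sapiens) (on this read-out lower numbers stand for stronger inhibition and higher numbers for weaker inhibition), compound 3 `C[C@H](C1CCCCC1)N(C)C(=O)c1ccc[nH]1` gives 1700000 nM. Among the three measured compounds this is the second highest number. Compound 1 `CN(CCCc1ccccc1)C(=O)c1cc2ccccc2[nH]1` gives 920000 nM, which lies within the usual scatter of the number for compound 3. Compound 2 `c1ccc(CNCc2ccc[nH]2)cc1` gives 350000000 nM, a far higher number than compound 3 and beyond the scatter, meaning much weaker inhibition. Compound 4 `C[C@@H](C1CCCCC1)N(C)C(=O)c1ccc[nH]1` is not yet measured. Compared with compound 3, (the two compounds have the same atoms and bonds and differ only in configuration as drawn: 1 of 1 stereo elements differ; a stereocentre at a saturated chain carbon is drawn R in compound 3 and S in compound 4). For the measured compounds named here, no measured pair shows what such a change does in this assay, so the expected step from compound 3 to compound 4 is none beyond the scatter, with the range kept wide to allow a shift either way, and that expectation corresponds to no change at the digits printed from compound 3 to compound 4 (within the scatter). Compound 4 is therefore expected to give about 1700000 nM, between 500000 nM and 6000000 nM.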

Compound 4, inhibition constant: 20000000 nM
Compound 4: the middle estimate sits 12-fold (1.07 log units) below what was measured, outside the stated range (above it).
By their numbers in this assay, from the lowest: compounds 1 and 3 (each within the scatter of the next); then compound 4; then compound 2.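

Drawing this saturated chain carbon S rather than R gives a 12-fold higher number from compound 3 to compound 4 (1.07 log units; beyond the scatter) in this assay, so the mirror-image change weakens inhibition well beyond the scatter. For the compounds shown here, none of the earlier compounds formed a pair that tested this carbon, and here the step can come only from the stereocentre, because nothing else separates the two: the fact that compounds 3 and 4 differ only in the configuration as drawn. The R drawing is therefore the one that inhibits more strongly in this pair. Still open, as far as these compounds go, is whether the same preference holds in compounds carrying an amine, a carboxylic acid or a longer chain.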